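The source may hold more compounds than are shown below. What is called first, only, known or untested is meant among the compounds shown, and "the series" means these compounds.

Working notes on the series. Among the measured compounds shown here, in a functional assay on L1210 cells (Mus musculus) for cytotoxicity, read by MTT assay, with a stated time of 24 h (on this read-out lower numbers stand for stronger inhibition and higher numbers for weaker inhibition), compound 1 (`COc1cc(C(=O)/C=C/c2ccc(C)cc2)cc(OC)c1OC`) gives 50500 nM, and it is the only compound here with a number. Compound 2 (`CCCCOc1ccc(/C=C/C(=O)c2cc(OC)c(OC)c(OC)c2)cc1`) reads > 100000 nM, which is a limit of the assay and not a number.

The next compound to be measured is compound 3 (`COc1cc(C(=O)/C=C/c2ccc(Cl)cc2Cl)cc(OC)c1OC`), which has 2,4-dichlorophenyl in place of 4-methylphenyl on a double-bonded chain carbon bound to a double-bonded chain carbon.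

For the measured compounds named here, only one measured step bears on this change: an at least 1.9-fold higher number from compound 1 to compound 2 (0.29 log units; that floor lies within the scatter). It swaps butoxy for methyl on an aromatic carbon, so it also alters the group that leaves in the new change, but it carries no chlorine and rests on a limit. It therefore gives only weak guidance on size or direction, and no step beyond the scatter can be argued from it.

The expected step in this assay is a 1.4-fold lower number from compound 1 to compound 3 (0.16 log units; within the scatter), and this remains an estimate with a wide margin. The estimated value for compound 3 is 35000 nM, with an expected range from 10000 nM to 100000 nM.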

Compound 3, half-maximal inhibitory concentration: 52500 nM
Beside the measured number, compound 3's estimate is 1.5-fold (0.18 log units) below it; measured number inside the range.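

In this assay, 2,4-dichlorophenyl in place of 4-methylphenyl on a double-bonded chain carbon bound to a double-bonded chain carbon gives a 1.0-fold higher number from compound 1 to compound 3 (0.02 log units; within the scatter), so the two compounds cannot be told apart. Among the compounds shown here, this is the first step at this place that is read between two numbers, and it shows that the place accepts 2,4-dichlorophenyl, with its two chlorine atoms, without a measurable difference from 4-methylphenyl in this read-out. Compound 2 remains a limit of the assay and not a number, so the butoxy step gives no measured size to set against this one: the limit of > 100000 nM in this assay, at which 1 of the 3 values shown sits.

The pair shown exchanges the methyl group for two chlorine atoms in a single change, which leaves open what one chlorine alone, or an amine or a carboxylic acid in the same group, would do at this place. Also open is whether any change to the shared core would give a step beyond the scatter, as all the compounds shown carry that core unchanged.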